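This account rests on a few compounds, and the source may have more. Where it says the series, first, only, none or still open, it means among the compounds named here.

Measured so far in a functional assay; a lower number here means a stronger inhibitor, a higher number a weaker inhibitor:
compound 1 `CC(C)=CCOc1cc(O)c2c(c1)OC(c1ccccc1)CC2=O`: 7320 nM
compound 2 `CC(C)=CCOc1cc(O)c2c(c1)OC(c1ccccc1Br)CC2=O`: 3820 nM

Only these two numbers exist for the series. For the measured compounds named here, the single step between them, a 1.9-fold lower number from compound 1 to compound 2 (0.28 log units; within the scatter), lies within the scatter, so compound 2 does not stand clearly apart from the only other measured member, and its value is best read as the same level of inhibition.

Compound 3 `CC(C)=CCOc1cc(O)c2c(c1)OC(c1ccc(C)cc1C)CC2=O` has not yet been measured in this assay. It carries 2,4-dimethylphenyl in place of 2-bromophenyl on a saturated ring carbon, next to the ring oxygen: 2,4-dimethylphenyl in place of 2-bromophenyl on a saturated ring carbon.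

One measured change bears on this, and it falls on the same aromatic group: bromo in place of hydrogen on an aromatic carbon, the step given above, which stayed within the scatter. Going by the values given here, no compound with a methyl group on that aromatic ring has been measured, so the data give no direction for the new group. With a single small step as the guide, no change beyond the scatter is expected, though the range has to stay wide.

The expected step is a 1.2-fold higher number from compound 2 to compound 3 (0.07 log units; within the scatter). For compound 3 the estimated value is 4500 nM, with an expected range of 1800 nM to 11000 nM.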

Compound 3, half-maximal inhibitory concentration: 6380 nM
The estimate for compound 3 lay 1.4-fold (0.15 log units) below the measured number; the range from low to high includes it.
By their numbers in this assay, from the lowest: compounds 2, 3 and 1 (each within the scatter of the next).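

In this assay, 2,4-dimethylphenyl in place of 2-bromophenyl on the saturated ring carbon next to the ring oxygen gives a 1.7-fold higher number from compound 2 to compound 3 (0.22 log units; within the scatter) and, set against the plain phenyl, gives a 1.1-fold lower number from compound 1 to compound 3 (0.06 log units; within the scatter) as well. The three aryl groups at this carbon therefore read as one level of inhibition, and two methyl groups now join a single bromo as a substitution that does not separate from the plain phenyl. The earlier pair rested on one substituent only, whereas this position has now been probed with a second kind of group on the same aromatic ring, still with no direction emerging. No measured evidence accompanies this result that could account for it.

Going by these compounds, every step at this carbon so far stays within the scatter, so it remains open whether an aromatic ring carrying an amine or a carboxylic acid would move the number clearly away from this level. The two methyl groups of 2,4-dimethylphenyl also enter together, which leaves what each contributes on its own unresolved.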